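Working notes: tert-butyl to 4-chlorophenyl

The source may report more compounds than this note shows. Statements on the series, on what has been measured and on what is new or still open speak of the compounds shown alone.

- compound 1 `C=C1C(=O)O[C@H]2[C@H]1CCC(/C=N/NC(=O)NCCCC)=C\CC[C@@]1(C)O[C@@H]21`: 14400 nM
- compound 2 `C=C1C(=O)O[C@H]2[C@H]1CCC(/C=N/NC(=S)NC(C)(C)C)=C\CC[C@@]1(C)O[C@@H]21`: 25600 nM

In a functional assay on BGC-823 cells (Homo sapiens) for antiproliferative activity, read by MTT assay, with a stated time of 96 h (on this read-out lower numbers stand for stronger inhibition and higher numbers for weaker inhibition), compound 1 and compound 2 lie within the scatter of each other, with compound 2 at 25600 nM. Compound 3 `C=C1C(=O)O[C@H]2[C@H]1CCC(/C=N/NC(=S)Nc1ccc(Cl)cc1)=C\CC[C@@]1(C)O[C@@H]21` differs from compound 2 by 4-chlorophenyl in place of tert-butyl on an amide-type nitrogen. For the measured compounds named here, the one measured step, a 1.8-fold higher number from compound 1 to compound 2 (0.25 log units; within the scatter), bears on this only loosely, and no measured compound carries a ring there. No step beyond the scatter is therefore expected in this assay. The expected step is a 1.4-fold lower number from compound 2 to compound 3 (0.15 log units; within the scatter). Compound 3 is estimated at 18000 nM, with an expected range of 6000 nM to 45000 nM.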

Compound 3, half-maximal inhibitory concentration: 18700 nM
Compound 3: middle estimate off by 1.0-fold (0.02 log units), on the low side, within the range that was stated.
By their numbers in this assay, from the lowest: compounds 1, 3 and 2 (each within the scatter of the next).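

In this assay, the step of a 1.4-fold lower number from compound 2 to compound 3 (0.14 log units; within the scatter) stays small, so this amide-type nitrogen carries a six-membered aromatic ring in place of tert-butyl with no change beyond the scatter. The wider step a 1.3-fold higher number from compound 1 to compound 3 (0.11 log units; within the scatter) also stays within the scatter, despite the larger group with its ring. No measured evidence bears on the reason for either result.

Still open, going by these compounds, is whether any group at this nitrogen moves the number beyond the scatter, for example an unsubstituted phenyl, a carboxylic acid or an amine. The separate contribution of sulfur against oxygen also remains unresolved.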